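A few compounds are considered here, and "the series" means these few. Any claim that something is new, unique, unknown or untested is made for them only; others in the source may bear on it.

Compound 1 `CCCCCCCCCCCCCCCCCCNC(=O)[C@H]1CSC(c2ccc(N(C)C)cc2)N1` carries a 4-(dimethylamino)phenyl group on the shared core. In a functional assay on LNCaP cells (Prostate gland, Homo sapiens) for antiproliferative activity, read by sulforhodamine B assay (on this read-out lower numbers stand for stronger inhibition and higher numbers for weaker inhibition), compound 1 gives 1600 nM, and on the numbers shown it stands lowest, though its only neighbour lies within the scatter of it: compound 2 `CCCCCCCCCCCCCCCCCCNC(=O)[C@H]1CSC(c2cccc(O)c2)N1`, which in this assay gives 1700 nM, the change being a 1.1-fold higher number from compound 1 to compound 2 (0.03 log units; within the scatter). Compound 3 `CCCCCCCCCCCCCCCCCCNC(=O)[C@H]1CSC(c2ccc(F)c(Br)c2)N1` has not yet been measured and differs from compound 1 in one place: 3-bromo-4-fluorophenyl in place of 4-(dimethylamino)phenyl on a saturated ring carbon. Going by the values given here, the one measured step that bears on this change is a swap of the same aryl group for a different one, and that swap produced a 1.1-fold higher number from compound 1 to compound 2 (0.03 log units; within the scatter). Among the compounds with values here, no measured step involves a 3-bromo-4-fluorophenyl group. Because a 1.1-fold higher number from compound 1 to compound 2 (0.03 log units; within the scatter) showed no movement beyond the scatter, compound 3 is expected to show a 1.1-fold higher number from compound 1 to compound 3 (0.05 log units; within the scatter), that is, no step beyond the scatter. The estimated value of compound 3 in this assay is 1800 nM, between 700 nM and 4500 nM.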

Compound 3, half-maximal inhibitory concentration: 3000 nM
Estimate against measurement, compound 3: 1.7-fold (0.22 log units) below; the measured number falls inside the stated range.
By their numbers in this assay, from the lowest: compounds 1, 2 and 3 (each within the scatter of the next).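

In this assay, the 3-bromo-4-fluorophenyl group on the saturated ring carbon gives a 1.9-fold higher number from compound 1 to compound 3 (0.27 log units; within the scatter) and a 1.8-fold higher number from compound 2 to compound 3 (0.25 log units; within the scatter) so all three aryl groups shown now lie within the scatter of one another. Compound 3 extends this to a group with fluorine and bromine on the ring, where the groups of compound 1 and compound 2 carry a dimethylamino group and a hydroxyl, so these three substitution patterns on the phenyl ring do not separate at this position. No measurement shown here offers an explanation for these numbers.

The compounds shown leave open whether a ring bearing a carboxylic acid, or a saturated cyclohexyl group in place of the phenyl ring, would also stay within the scatter. They also leave open how a shorter alkyl chain on the amide nitrogen would read alongside any of these aryl groups.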